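Swapping the aniline ring on the dimethoxyphenyl urea series

The compounds below may be only part of what the source reports. "The series", "measured", "known", "first", "only" and "open" are said of these compounds alone.

Three ureas built on the shared core of compound 1 `CCc1ccc(Nc2cc(NC(=O)Nc3c(Cl)cccc3Cl)ncn2)cc1` have been measured in a functional assay on NCI-H520 cells (Homo sapiens) for inhibition, read by MTT assay, with a stated time of 48 h, tested at 10 uM; a lower number here means less inhibition, a higher number more inhibition at the concentration tested (going by the name of the read-out). Compound 1 gives 31.5%. Compound 3 `CC(C)(C)c1cccc(Nc2cc(NC(=O)Nc3c(Cl)cccc3Cl)ncn2)c1` gives 29.6%. Compound 2 `COc1cc(NC(=O)Nc2cc(Nc3cccc(C(C)(C)C)c3)ncn2)cc(OC)c1` gives 13.1%, the lowest of the three numbers; its nearest neighbour is compound 3, and its furthest is compound 1, both beyond the scatter. The one single-site step among these compounds, a number 16.5 percentage points higher from compound 2 to compound 3 (beyond the scatter), concerns the urea-side ring, not the aniline.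

Compound 4 `CCc1ccc(Nc2cc(NC(=O)Nc3cc(OC)cc(OC)c3)ncn2)cc1` keeps the 3,5-dimethoxyphenyl urea of compound 2 and changes the other ring: 4-ethylphenyl in place of 3-(tert-butyl)phenyl on a nitrogen on an aromatic ring

Among the compounds with values here, no measured step covers this change directly. Compounds 1 and 3 carry the same pair of rings on the aniline nitrogen, with the dichlorophenyl urea in place of the dimethoxyphenyl one; compound 1 gives 31.5% and compound 3 gives 29.6%, and these two values lie within the scatter of each other, so the aniline swap shows no effect there. Compound 4 is therefore expected to stay close to compound 2, with a number 1.9 percentage points higher from compound 2 to compound 4 (within the scatter) expected to fall within the scatter. The estimate for compound 4 in this assay is 15%, with a range from 4% to 28%.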

Compound 4, a percentage reported as inhibition, at one concentration (the size of the read-out at that concentration, not a potency): 23.5%
Beside the measured number, compound 4's estimate is 8.5 percentage points below it; low and high end bracket the measured number.
By their numbers in this assay, from the lowest: compound 2; then compounds 4, 3 and 1 (each within the scatter of the next).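

In this assay, the ring on the aniline nitrogen makes a measurable difference when the urea carries 3,5-dimethoxyphenyl: 4-ethylphenyl in place of 3-(tert-butyl)phenyl on a nitrogen on an aromatic ring gives a number 10.4 percentage points higher from compound 2 to compound 4 (beyond the scatter), a modest step. The same exchange on the 2,6-dichlorophenyl urea connects compound 3 at 29.6% with compound 1 at 31.5%, two values within the scatter of each other, so among the compounds shown the aniline ring registers only in the 3,5-dimethoxyphenyl urea pair. Nothing available here accounts for this difference between the two urea pairs.

The compounds shown leave open whether the higher number goes with the ethyl group or with its place on the ring, a question that a 3-ethylphenyl or a 4-(tert-butyl)phenyl ring on the 3,5-dimethoxyphenyl urea would help to separate. As far as these compounds go, it also remains open how this position would respond to a ring carrying an amine or a carboxylic acid in place of the ethyl group, on either urea.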